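A few compounds are considered here, and "the series" means these few. Any claim that something is new, unique, unknown or untested is made for them only; others in the source may bear on it.

Compound 1 `Oc1ccc(-c2cc(-c3ccccc3F)cc(-c3ccccc3O)n2)cc1` gives in a functional assay on HeLa cells (Homo sapiens) for inhibition (a lower number here means a stronger inhibitor, a higher number a weaker inhibitor), only a limit, > 50000 nM.
Compound 2 `Oc1ccc(-c2cc(-c3cccc(F)c3)cc(-c3ccccc3O)n2)cc1` gives in this assay only a limit, > 50000 nM.
Compound 3 `Oc1ccccc1-c1cc(-c2ccccc2C(F)(F)F)cc(-c2ccccc2O)n1` gives in this assay 5800 nM.

Compound 3 stands as the only numeric result in the series; the other two values are limits (the limit of > 50000 nM in this assay, at which 2 of the 3 values shown sit). The step that the two limits leave unreadable from compound 1 to compound 2 is unreadable, as both of its ends are limits.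

Compound 4 `Oc1ccc(-c2cc(-c3ccccc3C(F)(F)F)cc(-c3ccccc3O)n2)cc1` differs from compound 3 by 4-hydroxyphenyl in place of 2-hydroxyphenyl on an aromatic carbon. Going by the values given here, no measured step follows this exchange of the hydroxyphenyl pattern. Compounds 1 and 2, which carry a 4-hydroxyphenyl group, both sit at the limit in this assay, yet each also differs from compound 4 in the other aryl group, so neither pair yields a readable step for the change in hand. The available data therefore leave the direction of the step open, with the two limits pointing toward weaker inhibition rather than stronger.

Compound 4 is estimated at 20000 nM in this assay, between 5000 nM and 60000 nM. This estimate implies a step of a 3.4-fold higher number from compound 3 to compound 4 (0.54 log units; beyond the scatter) toward weaker inhibition, expected to exceed the scatter.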

Compound 4, half-maximal inhibitory concentration: 16500 nM
Compound 4: the middle estimate sits 1.2-fold (0.08 log units) above what was measured; the measured number falls inside the stated range.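

In this assay, the exchange on the aromatic carbon next to the ring nitrogen can now be read between two numbers: a 2.8-fold higher number from compound 3 to compound 4 (0.45 log units; beyond the scatter). Going by these compounds alone, with the 2-(trifluoromethyl)phenyl group in place, the 2-hydroxyphenyl group therefore gives the stronger inhibitor, while compound 4 supplies the only number among the 4-hydroxyphenyl compounds and shows that this pattern is not inactive in itself. Changing the other aryl group gives an at least 3.0-fold lower number from compound 2 to compound 4 (0.48 log units; beyond the scatter) and an at least 3.0-fold lower number from compound 1 to compound 4 (0.48 log units; beyond the scatter), and both sizes are open-ended since each step starts from a limit: the limit of > 50000 nM in this assay, at which 2 of the 4 values shown sit.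

The compounds shown leave open how far the fluorophenyl compounds truly lie from compound 4 and whether the preference for the 2-hydroxyphenyl group holds with other aryl groups. Also open, going by these compounds, is what a 3-hydroxyphenyl group, or an amine or carboxylic acid in place of the hydroxyl, would give.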